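Replacing pyridin-3-yl with prop-1-en-1-yl: working notes

The source may report more compounds than this note shows. Statements on the series, on what has been measured and on what is new or still open speak of the compounds shown alone.

In an ADME assay on HepG2 2.2.15 cells (Homo sapiens) for cytotoxicity (a lower number here means that less compound is tolerated, a higher number that more compound is tolerated), compound 1 `CC(C)C(=O)OCCc1c(-c2ccccc2Cl)c2cc(Cl)ccc2[nH]c1=O` gives 62000 nM, compound 2 `CCCCC(=O)OCCc1c(-c2ccccc2Cl)c2cc(Cl)ccc2[nH]c1=O` gives 200000 nM and compound 3 `O=C(/C=C/c1cccnc1)OCCc1c(-c2ccccc2Cl)c2cc(Cl)ccc2[nH]c1=O` gives 39000 nM. The measured steps are a 1.6-fold lower number from compound 1 to compound 3 (0.20 log units; within the scatter) and a 5.1-fold lower number from compound 2 to compound 3 (0.71 log units; beyond the scatter), so compound 3 is level with compound 1 and sits under compound 2 alone. Compound 4 `C/C=C/C=C/C(=O)OCCc1c(-c2ccccc2Cl)c2cc(Cl)ccc2[nH]c1=O` differs from it by prop-1-en-1-yl in place of pyridin-3-yl on a double-bonded chain carbon bound to a double-bonded chain carbon, with prop-1-en-1-yl in place of pyridin-3-yl on a double-bonded chain carbon bound to a double-bonded chain carbon. Within the data shown here, no measured step covers this exchange. The closest guides are the two steps out of ring-free groups into compound 3, and a 3.2-fold higher number from compound 1 to compound 2 (0.51 log units; beyond the scatter) shows how widely those ring-free groups differ. Compound 1 stays level with compound 3, so only a modest rise in this assay is expected, and the expected step is a 2.1-fold higher number from compound 3 to compound 4 (0.31 log units; beyond the scatter). Compound 4 is estimated at 80000 nM, with an expected range of 30000 nM to 200000 nM.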

Compound 4, half-maximal cytotoxic concentration: 440000 nM
Beside the measured number, compound 4's estimate is 5.5-fold (0.74 log units) below it, and the stated range ends below it.
By their numbers in this assay, from the lowest: compounds 3 and 1 (each within the scatter of the next); then compound 2; then compound 4.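

In this assay, this position is far from indifferent: prop-1-en-1-yl in place of pyridin-3-yl on a double-bonded chain carbon bound to a double-bonded chain carbon gives a large step (an 11-fold higher number from compound 3 to compound 4 (1.05 log units; beyond the scatter)). Penta-1,3-dien-1-yl also outruns both other ring-free groups (a 2.2-fold higher number from compound 2 to compound 4 (0.34 log units; beyond the scatter); a 7.1-fold higher number from compound 1 to compound 4 (0.85 log units; beyond the scatter)), so compound 4 carries the highest number of the four. Losing the ring is not enough on its own, since ring-free compound 1 stays level with compound 3.

Nothing available explains the rise. Going by these compounds, whether it follows the ring nitrogen or the diene chain stays open, and phenyl in place of pyridin-3-yl would help separate the two.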